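Methoxy in place of methylsulfanyl on an aromatic carbon

The compounds below may be only part of what the source reports. "The series", "measured", "known", "first", "only" and "open" are said of these compounds alone.

In a functional assay on MCF7 cells (Homo sapiens) for cytotoxicity, read by MTT assay, with a stated time of 48 h (on this read-out higher numbers stand for weaker inhibition and lower numbers for stronger inhibition), compound 1 (`COc1cc(-c2ocnc2-c2cc(Br)c(OC)c(OC)c2)ccc1SC`) gives 2480 nM and compound 3 (`COc1ccc(-c2ocnc2-c2cc(Br)c(OC)c(OC)c2)cc1SC`) gives 2780 nM as its reading, so these two sit within the scatter of each other. Compound 2 (`COc1ccc(-c2ocnc2-c2cc(OC)c(SC)c(OC)c2)cc1O`) gives 450 nM as its reading, and compound 3 therefore stands beyond the scatter on the weaker side of it, level with compound 1.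

Compound 4 (`COc1ccc(-c2ocnc2-c2cc(Br)c(OC)c(OC)c2)cc1OC`) has not yet been measured. It differs from compound 3 by methoxy in place of methylsulfanyl on an aromatic carbon with methoxy in place of methylsulfanyl on an aromatic carbon, ortho to a methoxy group. Going by the values given here, no measured pair shows this exchange alone, so the data give no direct guide to it. A small step in this assay towards a lower number is expected, within the scatter or only slightly beyond it. The estimated 1.5-fold lower number from compound 3 to compound 4 (0.19 log units; within the scatter) is correspondingly modest. For compound 4 the expected value is 1800 nM with a range of 500 nM to 6000 nM in this estimate.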

Compound 4, half-maximal inhibitory concentration: 6100 nM
Beside the measured number, compound 4's estimate is 3.4-fold (0.53 log units) below it; the whole stated range lies below it.
By their numbers in this assay, from the lowest: compound 2; then compounds 1 and 3 (each within the scatter of the next); then compound 4.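

In this assay, methoxy in place of methylsulfanyl on this aromatic carbon, ortho to a methoxy group, is not neutral: it gives a 2.2-fold higher number from compound 3 to compound 4 (0.34 log units; beyond the scatter). The same exchange starting from compound 1 points the same way, with a 2.5-fold higher number from compound 1 to compound 4 (0.39 log units; beyond the scatter), so in this small set both compounds carrying methylsulfanyl read lower than the one carrying methoxy in its place. Nothing measured here accounts for this rise.

On these data alone, whether an amine or a longer chain such as ethylsulfanyl at this carbon would move the number further down or back up remains open. Compound 2 differs from these compounds in more than one place, so it leaves open whether the exchange would run the same way on a core without bromo.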